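Allyloxy in place of butoxy on a chloroquinoline core

This account rests on a few compounds, and the source may have more. Where it says the series, first, only, none or still open, it means among the compounds named here.

Compounds measured so far:
- compound 1 `CCCCOc1ccc2c(Cl)ccnc2c1`: 4130 nM
- compound 2 `CCCCCCCCOc1ccc2c(Cl)ccnc2c1`: 4300 nM
- compound 3 `Clc1ccnc2cc(OCCCc3ccccc3)ccc12`: 3610 nM

In a functional assay on SK-OV-3 cells (Homo sapiens) for cytotoxicity, read by MTT assay, with a stated time of 48 h (on this read-out higher numbers stand for weaker inhibition and lower numbers for stronger inhibition), compound 1 gives 4130 nM. Among the three numbers it is the second highest, and the gaps to compound 2 and to compound 3 lie within the scatter, so the three compounds cannot be told apart on this read-out. The unmeasured compound 4 `C=CCOc1ccc2c(Cl)ccnc2c1` differs from compound 1 by vinyl in place of propyl on a saturated chain carbon bound to an oxygen on an aromatic ring. Among the compounds with values here, two measured steps bear on this change, both of which alter the same chain on the aromatic oxygen: a 1.0-fold higher number from compound 1 to compound 2 (0.02 log units; within the scatter) and a 1.1-fold lower number from compound 1 to compound 3 (0.06 log units; within the scatter). Neither lengthening the chain nor ending it with a ring moved the number beyond the scatter. The change to compound 4 shortens the chain and introduces a double bond, which is not covered by any measured step, yet the evidence gathered here shows no sensitivity to this chain at all. The expected step is therefore a 1.0-fold higher number from compound 1 to compound 4 (0.01 log units; within the scatter), with no change beyond the scatter. Compound 4 is estimated at 4200 nM, within a range from 2000 nM to 9000 nM.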

Compound 4, half-maximal inhibitory concentration: 4030 nM
For compound 4 the middle estimate is 1.0-fold (0.02 log units) above the measured one; the measured number falls inside the stated range.
By their numbers in this assay, from the lowest: compounds 3, 4, 1 and 2 (each within the scatter of the next).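

In this assay, allyloxy in place of butoxy gives a 1.0-fold lower number from compound 1 to compound 4 (0.01 log units; within the scatter), so a shorter chain carrying a double bond does not move the number beyond the scatter. The earlier compounds shown here only showed the same for a longer saturated chain and for a chain ending in a phenyl ring, so an unsaturated chain is the new information at this oxygen. All four compounds now form a single run of numbers, each within the scatter of the next, and nothing available explains why the chain matters so little here.

Going by these compounds, all of these chains are built from carbon and hydrogen alone, so it remains open whether an amine or a carboxylic acid at the end of the chain would shift the number. On these data alone, it also remains open whether replacing the chlorine on the shared core would do so.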